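The source may hold more compounds than are shown below. What is called first, only, known or untested is meant among the compounds shown, and "the series" means these compounds.

Of the compounds shown here, three with a shared core have been measured so far. Compound 1, `CC(C)c1cc(NNC(=O)Nc2cc(Cl)nc(Cl)c2)nc2c1c(C(F)(F)F)nn2C`, gives 27200 nM in a functional assay on HCT-116 cells (Homo sapiens) for cytotoxicity, read by MTT assay, with a stated time of 48 h, in the presence of a further agent that is not named here; on this read-out lower numbers stand for an effect already at smaller amounts and higher numbers for an effect only at larger amounts of compound. Compound 2, `CCN(CC)c1cc(NC(=O)NNc2cc(-c3ccc(F)cc3)c3cnn(C)c3n2)cc(Cl)n1`, gives 29400 nM in this assay. Compound 3, `COc1cc(NC(=O)NNc2cc(-c3ccc(F)cc3)c3cnn(C)c3n2)cc(OC)c1OC`, gives 45300 nM in this assay. Compound 2 stands second highest of the three numbers, but its nearest neighbour, compound 1, and its furthest, compound 3, both lie within the usual scatter of it, so the three values cannot be told apart.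

The next compound, compound 4, `CCCCOc1cc(NC(=O)NNc2cc(-c3ccc(F)cc3)c3cnn(C)c3n2)cc(Cl)n1`, differs from compound 2 in one place: butoxy in place of diethylamino on an aromatic carbon.

For the measured compounds named here, no step between two measured compounds that differ in a single place is available. The three measured compounds differ from one another in this same outer region and still give indistinguishable numbers, so the step of a 1.0-fold higher number from compound 2 to compound 4 (0.01 log units; within the scatter) is expected to stay within the scatter, with no direction to it. Compound 4 is therefore expected to give about 30000 nM in this assay, in a range from 12000 nM to 75000 nM.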

Compound 4, half-maximal effective concentration: 49400 nM
Estimate against measurement, compound 4: 1.6-fold (0.22 log units) below; measured number inside the range.
By their numbers in this assay, from the lowest: compounds 1, 2, 3 and 4 (each within the scatter of the next).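

In this assay, butoxy in place of diethylamino on the aromatic carbon next to the ring nitrogen amounts to a 1.7-fold higher number from compound 2 to compound 4 (0.23 log units; within the scatter). For the compounds shown here, this is the first comparison in the set that isolates a single place, and it shows that a chain attached through oxygen and two ethyl groups attached through nitrogen cannot be told apart here, even though the earlier compounds could only hint at this across several differences at once. No measurement at hand speaks to why the two groups read alike.

Going by these compounds, it remains open whether a group of a different kind at this position, such as a primary amine, a carboxylic acid or a much longer chain, would move the number beyond the scatter. On these data alone, whether replacing the chloro group on the same ring would do so also remains open.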